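Methylsulfonyl in place of acetyl: a small expected step

The compounds below may be only part of what the source reports. "The series", "measured", "known", "first", "only" and "open" are said of these compounds alone.

In a physicochemical assay for lipophilicity, using the shake flask method, at pH 7.4 (a lower number here means a more polar compound, a higher number a more lipophilic compound), compound 1 `CN(C)[C@H]1CC[C@H](Nc2ncnc3[nH]ccc23)CC1` gives -0.6 and compound 2 `CN(C)[C@H]1CC[C@H](Nc2ncnc3[nH]cc(C4CCCC4)c23)CC1` gives 1.7. Compound 3 `CC(=O)N1CCN([C@H]2CC[C@H](Nc3ncnc4[nH]cc(C5CCOCC5)c34)CC2)CC1`, at 1.3, stands second highest of the three, with both gaps beyond the usual scatter. Compound 4 `CS(=O)(=O)N1CCN([C@H]2CC[C@H](Nc3ncnc4[nH]cc(C5CCOCC5)c34)CC2)CC1` carries methylsulfonyl in place of acetyl on an amine nitrogen in a ring. Among the compounds with values here, the only measured step, a number 2.30 log units higher from compound 1 to compound 2 (beyond the scatter), is large, but it puts cyclopentyl in place of hydrogen on an aromatic carbon, a different change in a different place, so it offers little guidance. Within the data shown here, no measured pair tests this swap. In this assay the expected step is a number 0.20 log units higher from compound 3 to compound 4 (within the scatter), small beside that one. For compound 4 the estimated value is 1.5, with an expected range from 1.1 to 1.9.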

Compound 4, distribution coefficient: 1.5
Compound 4: the middle estimate sits on the measured number at the digits printed; low and high end bracket the measured number.
By their numbers in this assay, from the lowest: compound 1; then compounds 3, 4 and 2 (each within the scatter of the next, the first and the last beyond it).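

In this assay, methylsulfonyl in place of acetyl on this amine nitrogen in a ring gives a number 0.20 log units higher from compound 3 to compound 4 (within the scatter), so this swap does not separate the two compounds. That holds even though methylsulfonyl brings one more heavy atom and 2 hydrogen-bond acceptors against 1 for acetyl. Nothing available explains this result.

Still open, from the compounds shown here alone, is whether a different group on this nitrogen, such as a carboxylic acid or a longer carbon chain, would give a step beyond the scatter. Going by these compounds, whether this swap behaves alike on another core also stays open.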